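Swapping Chloro for Amino in Compound 2

The compounds below may be only part of what the source reports. "The series", "measured", "known", "first", "only" and "open" are said of these compounds alone.

Compound 2, `Nc1nn(C(=O)Nc2ccc(Cc3ccccc3)cc2)c2ccc(Cl)cc12`, is tested in a functional assay on T47D cells (Homo sapiens) for antiproliferative activity, read by sulforhodamine B assay, with a stated time of 48 h; on this read-out higher numbers stand for lower toxicity in this test and lower numbers for higher toxicity in this test. In this assay compound 2 gives > 100000 nM, which is a limit of the assay and not a number. Compound 1, `Nc1nn(C(=O)Nc2ccc(Cc3ccccc3)cc2)c2ccccc12`, reaches only a limit here as well: in this assay compound 1 gives > 100000 nM, again a limit rather than a number. Among the compounds with values here, the single measured step, a step that the two limits leave unreadable from compound 1 to compound 2, therefore cannot be read in size, since the limit of > 100000 nM in this assay, at which 2 of the 2 values shown sit, describes where both values sit.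

Compound 3, `Nc1ccc2c(c1)c(N)nn2C(=O)Nc1ccc(Cc2ccccc2)cc1`, differs from compound 2 by amino in place of chloro on an aromatic carbon. Within the data shown here, no measured step bears directly on this exchange, and the only step available is unreadable, so the expectation rests on the two limits alone. Compound 3 is expected to stay at the same limit, with a number no higher from compound 2 to compound 3 (the limit leaves the size open) meaning no step beyond the scatter. The estimate for compound 3 in this assay is 100000 nM, within a range from 30000 nM to 300000 nM, with a large chance that only a limit is reported once more.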

Compound 3, concentration lethal to 50% of the cells: 66000 nM
For compound 3 the middle estimate is 1.5-fold (0.18 log units) above the measured one; the measured number falls inside the stated range.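

Within the data shown here, compound 3 is the first of the three to give a number rather than a limit, with 66000 nM in this assay, so a change at this aromatic carbon can bring a compound within the range that the test can put a number on, which chloro in place of hydrogen did not do. Amino in place of chloro gives an at least 1.5-fold lower number from compound 2 to compound 3 (0.18 log units; that floor lies within the scatter), and amino in place of hydrogen gives an at least 1.5-fold lower number from compound 1 to compound 3 (0.18 log units; that floor lies within the scatter). Both printed sizes are only floors within the scatter, so the result does not yet show a real gain in toxicity in this test, and the step from compound 1 to compound 2 still cannot be read.

On these data alone, the true size of both new steps stays open because compound 1 and compound 2 give no number to measure from: the limit of > 100000 nM in this assay, at which 2 of the 3 values shown sit. Also open is whether a hydroxyl group or a dimethylamino group on this same aromatic carbon would give a number as amino does, or would stay at a limit as chloro does.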